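An Ethoxyphenyl Replacement at the Edge of Measurability

The source may report more compounds than this note shows. Statements on the series, on what has been measured and on what is new or still open speak of the compounds shown alone.

Measured compounds in a functional assay on MCF7 cells (Homo sapiens) for antiproliferative activity, read by MTT assay, with a stated time of 48 h; on this read-out lower numbers stand for stronger inhibition and higher numbers for weaker inhibition:
- compound 1: `N#CC1=C(N)Oc2c(N)cc3nc4ccccc4nc3c2C12C(=O)N(Cc1cnnn1-c1ccccc1Cl)c1ccccc12`; compound 1 gives 34400 nM.
- compound 2: `COc1ccc(-n2nncc2CN2C(=O)C3(C(C#N)=C(N)Oc4c(N)cc5nc6ccccc6nc5c43)c3ccccc32)cc1`; compound 2 gives only a limit, > 50000 nM.

Compound 2 therefore stands at the upper limit of this assay, with no number of its own (the limit of > 50000 nM in this assay, at which 1 of the 2 values shown sits). Going by the values given here, the one measured step that touches the group on the aromatic nitrogen is an at least 1.4-fold higher number from compound 1 to compound 2 (0.16 log units; that floor lies within the scatter), a change that does not rise beyond the scatter and ends at a limit rather than a number, so it sets only a floor.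

Compound 3, `CCOc1ccccc1-n1nncc1CN1C(=O)C2(C(C#N)=C(N)Oc3c(N)cc4nc5ccccc5nc4c32)c2ccccc21`, differs from compound 2 by 2-ethoxyphenyl in place of 4-methoxyphenyl on an aromatic nitrogen. Among the compounds with values here, no measured step covers this particular exchange; the only neighbouring evidence is the small step from compound 1 to compound 2, which places the whole group near or beyond the limit of this assay. On that basis compound 3 is expected to show an at least 1.1-fold lower number from compound 2 to compound 3 (0.04 log units; that floor lies within the scatter), no step beyond the scatter, and a fair chance of again returning only a limit. Compound 3 is estimated at 45000 nM, within 20000 nM to 120000 nM.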

Compound 3, half-maximal inhibitory concentration: > 50000 nM
Compound 3: a limit, no number; the forecaster's own chance of this, stated with the estimate: 55%; middle value at least 1.1-fold (0.04 log units) away from the limit.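

In this assay compound 3 returns a limit and not a number, > 50000 nM, so a second alkoxy-bearing group on the aromatic nitrogen, here 2-ethoxyphenyl, ends at the same boundary as 4-methoxyphenyl: the limit of > 50000 nM in this assay, at which 2 of the 3 values shown sit. Set against the 2-chlorophenyl group, the exchange of ethoxy for chloro on an aromatic carbon gives an at least 1.4-fold higher number from compound 1 to compound 3 (0.16 log units; that floor lies within the scatter), which is only a floor and does not establish a change beyond the scatter. Going by these compounds alone, the step between the two limits cannot be read, so 2-ethoxyphenyl and 4-methoxyphenyl cannot be placed in any order, and the three compounds show only that compound 1 alone yields a number at this position.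

Going by these compounds, it remains open how far the true values of compound 2 and compound 3 lie beyond their limits, and whether any group on this phenyl ring would give a step clearly beyond the scatter. An amine, a carboxylic acid or a longer chain such as butoxy in place of ethoxy could test this, and so could a fluoro group in place of chloro.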